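A few compounds are considered here, and "the series" means these few. Any claim that something is new, unique, unknown or untested is made for them only; others in the source may bear on it.

Compound 1 `CCCSc1nc(N/N=C/c2c[nH]c3ccccc23)c2nnn(Cc3ccccc3)c2n1` gives 9010 nM in a functional assay on MCF7 cells (Homo sapiens) for antiproliferative activity, read by MTT assay, with a stated time of 72 h; on this read-out lower numbers stand for stronger inhibition and higher numbers for weaker inhibition.
Compound 2 `CCCSc1nc(N/N=C/c2ccccc2F)c2nnn(Cc3ccccc3)c2n1` gives > 64000 nM in this assay.

Compound 2 stands at the limit of this assay, (the limit of > 64000 nM in this assay, at which 1 of the 2 values shown sits), so for compound 2 only a boundary and no number is known. Compound 3 `CCCSc1nc(N/N=C/c2ccc([N+](=O)[O-])cc2)c2nnn(Cc3ccccc3)c2n1` differs from compound 2 in one place: 4-nitrophenyl in place of 2-fluorophenyl on a carbon with a double bond to nitrogen. Among the compounds with values here, the single measured step, an at least 7.1-fold higher number from compound 1 to compound 2 (0.85 log units; beyond the scatter), describes a different exchange on the same carbon and gives no direct guide to what a nitro group does there. Both measured compounds sit at weak inhibition, and the exchange of one six-membered aromatic ring of carbon only for another is expected to keep compound 3 in that weak region. Compound 3 is therefore expected to give 50000 nM, within a range from 12000 nM to 150000 nM. That estimate means an expected step of an at least 1.2-fold lower number from compound 2 to compound 3 (0.10 log units; that floor lies within the scatter), with no direction beyond the scatter claimed.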

Compound 3, half-maximal inhibitory concentration: 11000 nM
The estimate for compound 3 lay 4.5-fold (0.66 log units) above the measured number; measured number outside the range, below it.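

At this place, on a carbon with a double bond to nitrogen, two rings of the same kind do not behave alike, as 4-nitrophenyl in place of 2-fluorophenyl gives an at least 5.8-fold lower number from compound 2 to compound 3 (0.76 log units; beyond the scatter). That step has only a boundary at one end, as compound 2 is a limit in this assay: the limit of > 64000 nM in this assay, at which 1 of the 3 values shown sits. The 1H-indol-3-yl group is also not required for the level of inhibition seen with compound 1, as 4-nitrophenyl in its place gives a 1.2-fold higher number from compound 1 to compound 3 (0.09 log units; within the scatter).

The two phenyl groups differ in both the attached group and its printed ring number, so the compounds shown cannot separate these two changes; 4-fluorophenyl or 2-nitrophenyl would be needed to do so. They also leave open whether an amine or a carboxylic acid on the same ring would give a lower or a higher number.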